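Replacing a cyclohexyl ester with a butyl carbamate

The source may report more compounds than this note shows. Statements on the series, on what has been measured and on what is new or still open speak of the compounds shown alone.

Measured so far:
compound 1, `CCCCCCCCCC(=O)OCC1CN(C(=O)c2cc(OC)c(OC)c(OC)c2)CCN1C(=O)c1cc(OC)c(OC)c(OC)c1`, 2820 nM in a functional assay (Oryctolagus cuniculus) for inhibition of platelet-activating factor receptor (Cavia porcellus); a higher number here means a weaker inhibitor, a lower number a stronger inhibitor
compound 2, `COc1cc(C(=O)N2CCN(C(=O)c3cc(OC)c(OC)c(OC)c3)C(COC(=O)C3CCCCC3)C2)cc(OC)c1OC`, 290 nM in this assay

Compound 2 gives the lowest of the two numbers in this assay; the nearest is compound 1, and the step of a 9.7-fold lower number from compound 1 to compound 2 (0.99 log units; beyond the scatter) lies beyond the scatter. Within the data shown here, the only change in that step was cyclohexyl in place of nonyl on a carbonyl carbon, so exchanging a long chain for a ring at this position went with a markedly lower number.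

Compound 3, `CCCCNC(=O)OCC1CN(C(=O)c2cc(OC)c(OC)c(OC)c2)CCN1C(=O)c1cc(OC)c(OC)c(OC)c1`, has not been measured. It differs from compound 2 in one place: butylamino in place of cyclohexyl on a carbonyl carbon. The ring that distinguished compound 2 from compound 1 is gone again, and a shorter chain carrying a hydrogen-bond donor takes its place. Among the measured compounds shown here, no measured step covers a chain of this kind or a carbamate at this position, so the single step of a 9.7-fold lower number from compound 1 to compound 2 (0.99 log units; beyond the scatter) is the only guide. Since compound 3 loses the ring, its number is expected to move back up toward that of compound 1, though not necessarily all the way: the estimated step is a 3.4-fold higher number from compound 2 to compound 3 (0.54 log units; beyond the scatter). Compound 3 is therefore expected to give about 1000 nM in this assay, within a range from 300 nM to 3500 nM.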

Compound 3, half-maximal inhibitory concentration: 240 nM
Estimate against measurement, compound 3: 4.2-fold (0.62 log units) above, and the stated range ends above it.
By their numbers in this assay, from the lowest: compounds 3 and 2 (each within the scatter of the next); then compound 1.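

In this assay, butylamino in place of cyclohexyl on this carbonyl carbon gives a 1.2-fold lower number from compound 2 to compound 3 (0.08 log units; within the scatter), so among these compounds a ring is not needed for a number in this range: an open chain carrying a nitrogen does as well as the cyclohexyl group. The comparison with the long chain gives a 12-fold lower number from compound 1 to compound 3 (1.07 log units; beyond the scatter), which shows that the high number of compound 1 goes with the nonyl ester as such and not simply with the lack of a ring, as the first pair alone might have suggested. Nothing shown here explains why these groups give these numbers.

Butylamino differs from nonyl both in chain length and in bringing a nitrogen with its hydrogen, and these two changes arrive together, so the compounds shown do not say which of them goes with the lower number. A plain butyl ester and a nonyl carbamate would pull the two apart, and a cyclohexyl carbamate would show whether the ring and the nitrogen together give a number different from either one alone.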